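This account rests on a few compounds, and the source may have more. Where it says the series, first, only, none or still open, it means among the compounds named here.

Compound 1 `COc1cc(/C=C/C(=O)c2ccccc2F)cc(OC)c1OC` and compound 2 `COc1cc(OC)c(/C=C/C(=O)c2ccccc2F)c(OC)c1` carry three methoxy groups on a shared core. In a functional assay on A549 cells (Homo sapiens) for cytotoxicity, read by MTT assay, with a stated time of 72 h (a lower number here means a stronger inhibitor, a higher number a weaker inhibitor), compound 1 reaches only the limit of the assay, > 100000 nM, not a number. In this assay compound 2 likewise sits at the limit, > 100000 nM, not a number. Thus compound 2 stands at the ceiling where both measured values rest (the limit of > 100000 nM in this assay, at which 2 of the 2 values shown sit). Compound 3 `COc1ccc(/C=C/C(=O)c2ccccc2F)c(OC)c1` differs from compound 2 by hydrogen in place of methoxy on an aromatic carbon. Within the data shown here, for compound 3, the step of a number no higher from compound 2 to compound 3 (the limit leaves the size open) is expected to amount to none beyond the scatter, with no measured step to guide it. Compound 3 is estimated at 100000 nM, between 20000 nM and 300000 nM.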

Compound 3, half-maximal inhibitory concentration: 87.3 nM
Compound 3: middle estimate off by 1100-fold (3.06 log units), on the high side, and the stated range ends above it.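

In this assay, hydrogen in place of methoxy on this aromatic carbon, ortho to a large group and meta to two methoxy groups, gives an at least 1100-fold lower number from compound 2 to compound 3 (3.05 log units; beyond the scatter), a change large enough to lift the reading off the limit. The two earlier compounds, both resting at that limit, could not show that this single position matters so much. The size of the step remains a minimum, as compound 2 gives no number: the limit of > 100000 nM in this assay, at which 2 of the 3 values shown sit.

As far as these compounds go, whether a hydroxyl group, an amine or a chlorine atom at this position would behave like hydrogen or like methoxy remains open.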